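One Carbon Fewer in the Chain, in Two Settings

The compounds below may be only part of what the source reports. "The series", "measured", "known", "first", "only" and "open" are said of these compounds alone.

Compound 1 `COc1ccc(N(C)c2nc(C)nc3ccccc23)cc1OCCC[Se]C#N` gives 1040 nM in a functional assay on HepG2 cells (Homo sapiens) for inhibition, read by MTT assay, with a stated time of 48 h; on this read-out lower numbers stand for stronger inhibition and higher numbers for weaker inhibition.
Compound 2 `COc1ccc(N(C)c2nc(C)nc3ccccc23)cc1OCC[Se]C#N` gives 14 nM.
Compound 3 `COc1ccc(N(C)c2nc(C)nc3ccccc23)cc1C(=O)OCCCCCC[Se]C#N` gives 2650 nM.

Compounds 1 and 2 share a core and differ in one place: a group of 3 heavy atoms (1 carbon, 1 nitrogen, 1 selenium; no ring) in place of a group of 4 heavy atoms (2 carbon, 1 nitrogen, 1 selenium; no ring), on a saturated chain carbon, two bonds along the chain from an oxygen on an aromatic ring. That change made a 74-fold lower number from compound 1 to compound 2 (1.87 log units; beyond the scatter). Compound 4 `COc1ccc(N(C)c2nc(C)nc3ccccc23)cc1C(=O)OCCCCC[Se]C#N` is not yet measured; it differs from compound 3 by the same kind of change, (a group of 3 heavy atoms (1 carbon, 1 nitrogen, 1 selenium; no ring) in place of a group of 4 heavy atoms (2 carbon, 1 nitrogen, 1 selenium; no ring), on a saturated chain carbon, five bonds along the chain from an oxygen next to a carbonyl group), but here the chain sits five bonds along from an oxygen next to a carbonyl group rather than two bonds along from an oxygen on an aromatic ring. The difference between the cores of compound 1 and compound 3 is not broken down here. Among the compounds with values here, for compound 4 a smaller step is expected, a 2.9-fold lower number from compound 3 to compound 4 (0.47 log units; beyond the scatter), resting on the single earlier step of a 74-fold lower number from compound 1 to compound 2 (1.87 log units; beyond the scatter) and on the different surroundings of the chain. Compound 4 is expected to give about 900 nM in this assay, likely between 150 nM and 3000 nM.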

Compound 4, half-maximal inhibitory concentration: 667 nM
Compound 4: middle estimate off by 1.3-fold (0.13 log units), on the high side; the range from low to high includes it.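

In this assay, taking one carbon out of the chain lowered the number again on the second core, with a 4.0-fold lower number from compound 3 to compound 4 (0.60 log units; beyond the scatter). The direction of the change carried over from one core to the other, but its size did not: the same change on two cores in this assay, a 74-fold lower number (1.87 log units; beyond the scatter) from compound 1 to compound 2 and a 4.0-fold lower number (0.60 log units; beyond the scatter) from compound 3 to compound 4, 19-fold (1.27 log units) apart, beyond the scatter of two such steps With only these two pairs, this shows that the size of the step on one core is a poor guide to its size on another, but it does not show which difference between the cores sets that size.

On these data alone, it remains open whether a still shorter chain on the core of compound 3 would lower the number further. As far as these compounds go, the effect of sulfur in place of selenium also remains open.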